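The source may hold more compounds than are shown below. What is called first, only, known or untested is meant among the compounds shown, and "the series" means these compounds.

Measured so far:
- compound 1, `CCCCCCCCCCc1ccc(-c2noc(CCCCN)n2)cc1`: 55%
- compound 2, `CCCCCCCCCCc1ccc(-c2c[nH]c(CCCN)n2)cc1`: 63%

Both compounds were tested in an assay on HeLa cells for inhibition of sphingosine-1-phosphate transporter SPNS2 (Mus musculus), read by LC-MS, tested at 2 uM; on this read-out higher numbers stand for more inhibition at the one concentration tested (going by the name of the read-out) and lower numbers for less inhibition. On this read-out compound 1 gives 55% and compound 2 gives 63%; the two values lie within the usual scatter of each other, so neither compound can be set above the other on these numbers alone. Compound 3, `CCCCCCCCCCc1ccc(-c2cn(C)c(CCCN)n2)cc1`, has not yet been measured. It differs from compound 2 in one place: methyl in place of hydrogen on an aromatic nitrogen. Among the compounds with values here, no measured pair shows what such a change does here, so the expectation rests only on the two values in hand, which sit close together although their cores differ. The step of a number 9 percentage points lower from compound 2 to compound 3 (within the scatter) is therefore expected to be small, more likely downward than upward, and quite possibly within the scatter. For compound 3 the estimate in this assay is 54%, with a range from 35% to 72%.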

Compound 3, a percentage reported as inhibition, at one concentration (the size of the read-out at that concentration, not a potency): 51%
Compound 3: middle estimate off by 3 percentage points, on the high side; the measured number falls inside the stated range.
By their numbers in this assay, from the lowest: compounds 3, 1 and 2 (each within the scatter of the next, the first and the last beyond it).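

Placing methyl in place of hydrogen on the aromatic nitrogen gives the first measured step at this position, and this assay records a number 12 percentage points lower from compound 2 to compound 3 (beyond the scatter) as a modest drop beyond the usual scatter. The hydrogen on this nitrogen is therefore not essential, since compound 3 still gives 51% inhibition at the one concentration tested, but replacing it with methyl does carry a measurable cost. No measurement here explains the drop or separates the loss of the hydrogen from the arrival of the methyl.

One step cannot show whether the effect belongs to methyl alone or continues with other groups. An ethyl or a 2-hydroxyethyl group on the same nitrogen would show whether the number keeps falling or partly recovers.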